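Swapping the amide amine in a stilbene series

The source may hold more compounds than are shown below. What is called first, only, known or untested is meant among the compounds shown, and "the series" means these compounds.

Three analogues sharing one core have been measured in a functional assay on B16-F10 cells (Mus musculus) for inhibition, read by MTT assay, with a stated time of 48 h; on this read-out lower numbers stand for stronger inhibition and higher numbers for weaker inhibition. Compound 1 `COc1ccc(/C=C/c2cc(OC)cc(OC)c2/C=C/C(=O)N2CCN(C)CC2)cc1` gives 5670 nM. Compound 2 `COc1ccc(/C=C/c2cc(OC)cc(OC)c2/C=C/C(=O)N2CCCC2)cc1` gives 9280 nM, and compound 3 `CCCCNC(=O)/C=C/c1c(/C=C/c2ccc(OC)cc2)cc(OC)cc1OC` gives 2080 nM. Among these three numbers compound 1 has the second highest; its nearest neighbour is compound 2, the step of a 1.6-fold higher number from compound 1 to compound 2 (0.21 log units; within the scatter), while the furthest is compound 3, the step of a 2.7-fold lower number from compound 1 to compound 3 (0.44 log units; beyond the scatter).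

Compound 4 `COc1ccc(/C=C/c2cc(OC)cc(OC)c2/C=C/C(=O)N2CCC(c3ccccc3)CC2)cc1` is not yet measured. It differs from compound 1 in one place: 4-phenylpiperidin-1-yl in place of 4-methylpiperazin-1-yl on a carbonyl carbon. Both the group that leaves and the group that enters are ring amines joined to the carbonyl carbon, so compound 4 remains a tertiary amide, like compound 1 and compound 2.

Going by the values given here, two measured steps bear on this change. Exchanging one ring amine for another, a 1.6-fold higher number from compound 1 to compound 2 (0.21 log units; within the scatter), stayed within the scatter. Only the move to an open-chain butylamino group, a 2.7-fold lower number from compound 1 to compound 3 (0.44 log units; beyond the scatter) and a 4.5-fold lower number from compound 2 to compound 3 (0.65 log units; beyond the scatter), gave a modest lowering. Because a 1.6-fold higher number from compound 1 to compound 2 (0.21 log units; within the scatter) was within the scatter, no step beyond the scatter is expected for compound 4 in this assay, and the estimated step is a 1.0-fold lower number from compound 1 to compound 4 (0.01 log units; within the scatter). Compound 4 is therefore expected to give 5500 nM, with a range from 2000 nM to 14000 nM.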

Compound 4, half-maximal inhibitory concentration: 9180 nM
Estimate against measurement, compound 4: 1.7-fold (0.22 log units) below; low and high end bracket the measured number.
By their numbers in this assay, from the lowest: compound 3; then compounds 1, 4 and 2 (each within the scatter of the next).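

In this assay, adding an aromatic ring of carbon only and giving up the second ring nitrogen does not move the number beyond the scatter (a 1.6-fold higher number from compound 1 to compound 4 (0.21 log units; within the scatter)), and the new group also sits level with pyrrolidin-1-yl (a 1.0-fold lower number from compound 2 to compound 4 (0.00 log units; within the scatter)). With three different ring amines on the carbonyl carbon, the numbers for compound 1, compound 2 and compound 4 all lie within the scatter of one another, so in this small set, the ring amines tolerate a wide change in the group they carry, while butylamino remains set apart (a 4.4-fold higher number from compound 3 to compound 4 (0.64 log units; beyond the scatter)). Nothing available here explains why these ring amines read alike or why compound 3 differs.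

Compound 3 differs from the other three both in having an open chain and in keeping the amide hydrogen, so these compounds cannot show which of the two goes with its lower number. A diethylamino group (open chain, no amide hydrogen) and a cyclohexylamino group (ring, with the amide hydrogen) could separate the two, and a longer chain such as hexylamino could show whether chain length matters.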